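The source may report more compounds than this note shows. Statements on the series, on what has been measured and on what is new or still open speak of the compounds shown alone.

Measured compounds in an assay on HEK-293T cells for inhibition of diacylglycerol lipase-alpha (Homo sapiens), read by colorimetric assay; on this read-out lower numbers stand for stronger inhibition and higher numbers for weaker inhibition:
compound 1 `O=C(CCCCCCc1ccccc1)c1nc(Cl)co1` — 2400 nM
compound 2 `CNC(=O)c1coc(C(=O)CCCCCCc2ccccc2)n1` — > 10000 nM (a limit of the assay, not a number)

Compound 2 stands only at the limit of this assay (the limit of > 10000 nM in this assay, at which 1 of the 2 values shown sits); no number is known for compound 2. Among the measured compounds shown here, the single measured step, an at least 4.1-fold higher number from compound 1 to compound 2 (0.61 log units; beyond the scatter), runs toward weaker inhibition and is itself bounded by that limit, so its true size is open.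

Compound 3 `O=C(CCCCCCc1ccccc1)c1nc(-c2ccncc2)co1` differs from compound 2 by pyridin-4-yl in place of methylcarbamoyl on an aromatic carbon. For the measured compounds named here, no measured step exchanges methylcarbamoyl for an aromatic group at this position, so the step from compound 1 to compound 2 bears on it only indirectly: it shows that this position tolerates a change in potency of at least modest size. The starting point, compound 2, sits at a limit, so any return toward a measurable number would appear as a move to stronger inhibition in this assay. Compound 1 at 2400 nM shows that a small substituent at this position is compatible with a measurable value.

Compound 3 is therefore expected near 5000 nM, within 800 nM to 30000 nM. This corresponds to an expected step of an at least 2.0-fold lower number from compound 2 to compound 3 (0.30 log units; that floor lies within the scatter), with a real chance that only a limit is reported again.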

Compound 3, half-maximal inhibitory concentration: > 10000 nM
Compound 3: no number, only a limit (the forecaster's own chance of this, stated with the estimate: 40%); at least 2.0-fold (0.30 log units) between middle value and limit.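

In this assay compound 3 gives > 10000 nM, which is a limit of the assay and not a number. Pyridin-4-yl in place of chloro on this aromatic carbon gives an at least 4.1-fold higher number from compound 1 to compound 3 (0.61 log units; beyond the scatter), so a second replacement of chloro, this one with no hydrogen-bond donor, also ends at the limit, and the loss seen with methylcarbamoyl is not tied to that group alone. The step between compound 2 and compound 3 cannot be read, and chloro remains the only group at this position with a measured number, since the other two values shown are limits: the limit of > 10000 nM in this assay, at which 2 of the 3 values shown sit.

Still open, from the compounds shown here alone, is whether any other group on this carbon, such as bromo, methyl or a small amine, keeps a measurable number, and how far compound 2 and compound 3 actually lie from each other. Also open, going by these compounds, is how the core with plain hydrogen on this carbon compares with compound 1, which would show whether chloro itself adds to the inhibition.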